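Adding a basic ring to a urea quinazoline anilide

The source may report more compounds than this note shows. Statements on the series, on what has been measured and on what is new or still open speak of the compounds shown alone.

Measured compounds in a functional assay on A549 cells (Homo sapiens) for antiproliferative activity, read by MTT assay, with a stated time of 72 h; on this read-out higher numbers stand for weaker inhibition and lower numbers for stronger inhibition:
compound 1 `CN1CCN(Cc2ccc(NC(=O)Nc3ccc4ncnc(Nc5cccc(C(F)(F)F)c5)c4c3)cc2)CC1`: 1650 nM
compound 2 `O=C(Nc1ccc(CN2CCCC2)cc1)Nc1ccc2ncnc(Nc3cccc(C(F)(F)F)c3)c2c1`: 830 nM
compound 3 `O=C(Nc1ccccc1)Nc1ccc2ncnc(Nc3cccc(C(F)(F)F)c3)c2c1`: > 10000 nM, which is a limit of the assay and not a number

All three compounds share the same core; they differ only in what sits on the outer phenyl ring of the urea. Compound 3 carries nothing there, and in this assay compound 3 sits at the limit of > 10000 nM in this assay, at which 1 of the 3 values shown sits, so only a bound is known for it. Compound 1 and compound 2 carry a basic ring joined through a saturated carbon, and both give a number. The step of a 2.0-fold lower number from compound 1 to compound 2 (0.30 log units; within the scatter) shows that the two rings behave alike. The steps of an at least 6.0-fold higher number from compound 1 to compound 3 (0.78 log units; beyond the scatter) and an at least 12-fold higher number from compound 2 to compound 3 (1.08 log units; beyond the scatter) show that removing that group costs a good deal of activity.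

Compound 4 `CN1CCN(c2ccc(NC(=O)Nc3ccc4ncnc(Nc5cccc(C(F)(F)F)c5)c4c3)cc2)CC1` differs from compound 3 by 4-methylpiperazin-1-yl in place of hydrogen on an aromatic carbon. Among the compounds with values here, the ring is the one found in compound 1, but attached without the saturated carbon. The measured steps suggest that putting a basic ring back at this position restores potency, so a step of an at least 3.3-fold lower number from compound 3 to compound 4 (0.52 log units; beyond the scatter) towards a stronger number is expected, though the missing linker leaves the size uncertain. Compound 4 is therefore estimated at 3000 nM, within 800 nM to 10000 nM.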

Compound 4, half-maximal inhibitory concentration: 2760 nM
The estimate for compound 4 lay 1.1-fold (0.04 log units) above the measured number, within the range that was stated.
By their numbers in this assay, from the lowest: compounds 2, 1 and 4 (each within the scatter of the next, the first and the last beyond it). At a limit, above all of these: compound 3.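

Compound 3 is held only at a limit of the assay, not at a number: the limit of > 10000 nM in this assay, at which 1 of the 4 values shown sits.

Even so, the step of an at least 3.6-fold lower number from compound 3 to compound 4 (0.55 log units; beyond the scatter) shows that 4-methylpiperazin-1-yl can bring activity at this position without a saturated carbon to link it to the aromatic ring. The step of a 1.7-fold higher number from compound 1 to compound 4 (0.22 log units; within the scatter) adds that removing this carbon leaves the result within the scatter in this assay, so compound 1 and compound 4 cannot be told apart here. The step of a 3.3-fold higher number from compound 2 to compound 4 (0.52 log units; beyond the scatter) lies beyond the scatter, but the ring and the link change together in it, so it does not tell which of the two changes matters.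

Still open, going by these compounds, is whether pyrrolidin-1-yl set directly on the aromatic carbon would behave like compound 4 or like compound 2, and whether a longer chain carrying either ring would hold the activity. Also open, on these data alone, is whether a ring is needed at all, or whether a simple open-chain amine on the same carbon would serve, and what a carboxylic acid there would do.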